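The compounds below may be only part of what the source reports. "The series", "measured", "known", "first", "only" and "open" are said of these compounds alone.

Measured so far:
Compound 1, `C=CC[N+](C)(C)c1cccc(O)c1`, gives 13000 nM in a functional assay with Cavia porcellus as the target; a higher number here means a weaker inhibitor, a lower number a stronger inhibitor.
Compound 2, `C=CC[N+](C)(C)c1cccc(OC)c1`, reaches only a limit of this assay, > 3000 nM.
Compound 3, `C[N+](C)(Cc1ccccc1)c1ccccc1O`, likewise reaches only a limit of this assay, > 3000 nM.

All three carry a positively charged nitrogen attached to an aromatic ring, and compound 1 is the only one of them with an actual number in this assay. The change from compound 1 to compound 2 is methyl in place of hydrogen on an oxygen on an aromatic ring, and the step it made, a step that the limit leaves unreadable from compound 1 to compound 2, has no readable size because of the limit of > 3000 nM in this assay, at which 2 of the 3 values shown sit. Compound 3 differs from compound 1 by a larger part of the molecule, and the difference between the two cores is not broken down here.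

Compound 4, `COc1ccccc1[N+](C)(C)Cc1ccccc1`, has not been measured. Among the compounds with values here, it arises from compound 3 by methyl in place of hydrogen on an oxygen on an aromatic ring, the same change as the one from compound 1 to compound 2, made at a place described in the same words. For compound 4 a weak result in this assay is expected, with an estimated step that the limit leaves unreadable from compound 3 to compound 4. This rests on the limit at which compound 3 stands, > 3000 nM. It rests as well on a step that the limit leaves unreadable from compound 1 to compound 2, which gave no readable size. Compound 4 is therefore estimated at 15000 nM in this assay, expected to lie somewhere between 3000 nM and 60000 nM, and most likely reported only as a limit.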

Compound 4, half-maximal inhibitory concentration: > 3000 nM
Compound 4 ended at the assay's limit; the forecaster's own chance of this, stated with the estimate: 70%; the middle value lies beyond the limit too.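

Compound 3 and compound 4 both stand at a limit of this assay rather than at a number, so the hydroxy to methoxy change between them has no size that can be read: the limit of > 3000 nM in this assay, at which 3 of the 4 values shown sit.

The compounds shown leave open how strong compound 2, compound 3 and compound 4 really are in this assay and whether this change on the oxygen shifts the result at all.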